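The source may hold more compounds than are shown below. What is called first, only, known or untested is meant among the compounds shown, and "the series" means these compounds.

Working notes on the series. In a functional assay on PC-3 cells (Homo sapiens) for antiproliferative activity, read by MTT assay, with a stated time of 72 h (a lower number here means a stronger inhibitor, a higher number a weaker inhibitor), compound 1 `COc1cc2ncnc(N3CCc4ccccc43)c2cc1NC(=O)/C=C/C(C)C` gives 6530 nM. Compound 2 `COc1cc2ncnc(N3CCCc4ccccc43)c2cc1NC(=O)/C=C/C(C)C` gives 8430 nM in this assay, and compound 3 `CC(C)/C=C/C(=O)Nc1cc2c(N3CCCc4ccccc43)ncnc2cc1O[C@@H]1CCOC1` gives 8510 nM. Compound 2 stands second highest of the three numbers; its nearest neighbour is compound 3, with a 1.0-fold higher number from compound 2 to compound 3 (0.00 log units; within the scatter), and its furthest is compound 1, with a 1.3-fold higher number from compound 1 to compound 2 (0.11 log units; within the scatter), so all three sit inside one band of scatter. Both measured steps change the part of the molecule attached to the shared core or the group on the ring oxygen, and neither touches the amide side chain.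

Compound 4 `COc1cc2ncnc(N3CCCc4ccccc43)c2cc1NC(=O)/C=C/CN1CCCC1` differs from compound 2 by (pyrrolidin-1-yl)methyl in place of isopropyl on a double-bonded chain carbon bound to a double-bonded chain carbon. Among the measured compounds shown here, none of the measured steps bears on this position, since the amide side chain is held constant across compounds 1, 2 and 3, so the only guidance is indirect: the two changes that were tried elsewhere stayed within the scatter. On that basis the expected step is a 1.7-fold lower number from compound 2 to compound 4 (0.23 log units; within the scatter), which is no change beyond the scatter, with the range kept wide to cover an untested position. Compound 4 is therefore estimated at 5000 nM in this assay, between 1500 nM and 15000 nM.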

Compound 4, half-maximal inhibitory concentration: 1740 nM
Beside the measured number, compound 4's estimate is 2.9-fold (0.46 log units) above it; the range from low to high includes it.
By their numbers in this assay, from the lowest: compound 4; then compounds 1, 2 and 3 (each within the scatter of the next).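

In this assay the amide side chain proves to be a position that can move the number: the step of a 4.8-fold lower number from compound 2 to compound 4 (0.69 log units; beyond the scatter) is the only one shown that lies beyond the scatter, whereas the steps of a 1.3-fold higher number from compound 1 to compound 2 (0.11 log units; within the scatter) and a 1.0-fold higher number from compound 2 to compound 3 (0.00 log units; within the scatter) both stay within it. The change at this position replaces isopropyl, which has no ring and no hydrogen-bond acceptor, with (pyrrolidin-1-yl)methyl, which carries a five-membered non-aromatic ring and a nitrogen as its hydrogen-bond acceptor, so ring and nitrogen enter together and this single pair cannot separate them. No supporting measurement is available to explain the shift.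

Whether the nitrogen or the ring accounts for the step stays open, and (dimethylamino)methyl, an open-chain amine, or (morpholin-4-yl)methyl, a ring with a second hetero atom, at the same place would help to tell these apart. Also open, from the compounds shown here alone, is whether (pyrrolidin-1-yl)methyl has the same effect with the other groups on the shared core, such as the 2,3-dihydro-1H-indol-1-yl of compound 1, or with the oxolan-3-yl on the oxygen of compound 3.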